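The source may hold more compounds than are shown below. What is called first, only, known or untested is meant among the compounds shown, and "the series" means these compounds.

Measured in a functional assay on the whole organism with Mus musculus as the target; on this read-out lower numbers stand for an effect already at smaller amounts and higher numbers for an effect only at larger amounts of compound:
- compound 1 `Cc1c(N)c(C)c2c(c1CN(C)C)OC(C)(C)C2`: > 50 mg/kg (a limit)
- compound 2 `Cc1c(N)c(C)c2c(c1CC(C)C)OC(C)(C)C2`: 13.3 mg/kg
- compound 3 `Cc1c(C)c2c(c(C)c1N)CC(C)(CSc1ccc(O)cc1)O2`: > 50 mg/kg (a limit)

Compound 3 has no exact number, only a limit: the limit of > 50 mg/kg in this assay, at which 2 of the 3 values shown sit. So its true position is unknown, and compound 3 can be compared with the others only loosely.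

Compound 4 `Cc1c(C)c2c(c(C)c1N)CC(C)(CSCCO)O2` keeps the core of compound 3 but has 2-hydroxyethyl in place of 4-hydroxyphenyl on a sulfur. Going by the values given here, no measured step changes a group at this place. The nearest guide is an at least 3.7-fold lower number from compound 1 to compound 2 (0.57 log units; beyond the scatter), which comes from isopropyl in place of dimethylamino on a saturated chain carbon bound to an aromatic carbon. Among the compounds with values here, that step lies beyond the usual scatter, but it involves different groups at a different place, so it shows only that swapping one side group can shift the read-out in this assay.

A modest move towards a lower number is therefore expected, although this assay may again report only a limit. The expected change is an at least 1.2-fold lower number from compound 3 to compound 4 (0.09 log units; that floor lies within the scatter). For compound 4 the estimated value is 40 mg/kg. The expected range runs from 15 mg/kg to 100 mg/kg.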

Compound 4, dose for 50% inhibition: > 50 mg/kg
Compound 4: no number, only a limit (the forecaster's own chance of this, stated with the estimate: 55%); middle value at least 1.2-fold (0.09 log units) from the limit.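

In this assay, compound 3 and compound 4 each give only a limit, so the step between these two compounds cannot be read: the limit of > 50 mg/kg in this assay, at which 3 of the 4 values shown sit.

The compounds shown leave open whether 2-hydroxyethyl in place of 4-hydroxyphenyl on a sulfur shifts the read-out at all, and in which direction.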